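Replacing thiophen-3-yl with 2-hydroxyphenyl on the shared core

A few compounds are considered here, and "the series" means these few. Any claim that something is new, unique, unknown or untested is made for them only; others in the source may bear on it.

In a functional assay on HCT-116 cells (Homo sapiens) for inhibition, with a stated time of 72 h (a higher number here means a weaker inhibitor, a lower number a stronger inhibitor), compound 1 (`NC1CCC(Nc2nc(NCc3ccc(-c4ccccc4)nc3)c3ncn(C4CCCC4)c3n2)CC1`) gives 563 nM while compound 2 (`NC1CCC(Nc2nc(NCc3ccc(-c4cccs4)nc3)c3ncn(C4CCCC4)c3n2)CC1`) gives 97 nM and compound 3 (`NC1CCC(Nc2nc(NCc3ccc(-c4ccsc4)nc3)c3ncn(C4CCCC4)c3n2)CC1`) gives 145 nM as its value. The two thiophene compounds are separated only by a 1.5-fold higher number from compound 2 to compound 3 (0.17 log units; within the scatter) which lies within the scatter. Both stand apart from the phenyl compound, with a 3.9-fold lower number from compound 1 to compound 3 (0.59 log units; beyond the scatter) and a 5.8-fold lower number from compound 1 to compound 2 (0.76 log units; beyond the scatter) both modest but beyond the scatter.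

Compound 4 (`NC1CCC(Nc2nc(NCc3ccc(-c4ccccc4O)nc3)c3ncn(C4CCCC4)c3n2)CC1`) carries 2-hydroxyphenyl in place of thiophen-3-yl on an aromatic carbon next to the ring nitrogen, with 2-hydroxyphenyl in place of thiophen-3-yl on an aromatic carbon as the counted difference. Among the measured compounds shown here, no measured step tests 2-hydroxyphenyl itself. The closest guide is compound 1 with its plain phenyl group, and the relevant measure is a 3.9-fold lower number from compound 1 to compound 3 (0.59 log units; beyond the scatter) read in reverse. A modest move to a higher number is therefore expected in this assay for this change. The estimated step is a 1.9-fold higher number from compound 3 to compound 4 (0.29 log units; within the scatter) on that reading. For compound 4 the estimated value is 280 nM with an expected range from 90 nM to 800 nM around it.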

Compound 4, half-maximal inhibitory concentration: 35 nM
The estimate for compound 4 lay 8.0-fold (0.90 log units) above the measured number, and the stated range ends above it.
By their numbers in this assay, from the lowest: compound 4; then compounds 2 and 3 (each within the scatter of the next); then compound 1.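

On an aromatic carbon next to the ring nitrogen, hydroxy in place of hydrogen on the phenyl group gives a 16-fold lower number from compound 1 to compound 4 (1.21 log units; beyond the scatter) in this assay, the only large step among these compounds. The thiophene groups had outperformed plain phenyl, but that order does not carry over to 2-hydroxyphenyl, which gives a 4.1-fold lower number from compound 3 to compound 4 (0.62 log units; beyond the scatter) and a 2.8-fold lower number from compound 2 to compound 4 (0.44 log units; beyond the scatter) and so makes compound 4 the strongest inhibitor of the four. The compounds shown include no measurement that accounts for this gain.

They leave open whether a methoxy group or an amine in place of the hydroxy group would retain the gain, and whether 3-hydroxyphenyl or 4-hydroxyphenyl would match 2-hydroxyphenyl. They also leave open whether a hydroxy group on a thiophene ring would produce a comparable step.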